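The compounds below may be only part of what the source reports. "The series", "measured", "known", "first", "only" and "open" are said of these compounds alone.

The three measured compounds share one core and are compared in a functional assay on the whole organism (strain Wister albino) for inhibition, with Rattus norvegicus as the target, read by paw edema, with stated times of 1 h and 2 h, at a dose of 50 mg/kg by the intraperitoneal route; a higher number here means more inhibition at the dose given (going by the name of the read-out), a lower number less inhibition. Compound 1 `CCOC(=O)c1c(-c2ccc(Cl)cc2)cc(-c2ccccc2)nc1N1CCCCC1` gives 29.1%. Compound 2 `CCOC(=O)c1c(-c2ccc(Cl)c(Cl)c2)cc(-c2ccccc2)nc1N1CCCCC1` carries the change chloro in place of hydrogen on an aromatic carbon and gives 67.9%, so the step is a number 38.8 percentage points higher from compound 1 to compound 2 (beyond the scatter). Compound 3 `CCOC(=O)c1c(-c2ccc(Cl)cc2)cc(-c2ccccc2)nc1Nc1ccc(Cl)cc1` differs from compound 1 by (4-chlorophenyl)amino in place of piperidin-1-yl on an aromatic carbon, and compound 3 gives 40.6%, a step of a number 11.5 percentage points higher from compound 1 to compound 3 (beyond the scatter). Compound 3 thus stands between the other two measured compounds.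

Compound 4 `CCOC(=O)c1c(-c2ccc(Cl)c(Cl)c2)cc(-c2ccccc2)nc1Nc1ccc(Cl)cc1` has not yet been measured in this assay. It differs from compound 3 by chloro in place of hydrogen on an aromatic carbon, the same change that turned compound 1 into compound 2, and the surroundings of the place are described in the same words for both pairs, so this is the same change on a different core. Among the compounds with values here, since the one earlier example of this change is a large gain, the step expected here is a number 34.4 percentage points higher from compound 3 to compound 4 (beyond the scatter), which rests on the fact that the same change gave a number 38.8 percentage points higher from compound 1 to compound 2 (beyond the scatter). A somewhat smaller gain is allowed for, because compound 3 already starts from 40.6%. Compound 4 is therefore expected to reach about 75%, within a range of 55% to 92%.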

Compound 4, a percentage reported as inhibition, in the whole organism at one dose (the size of the read-out at that dose, not a potency): 61.9%
Compound 4: middle estimate off by 13.1 percentage points, on the high side; the range from low to high includes it.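

In this assay, the change from 4-chlorophenyl to 3,4-dichlorophenyl again raises the number, giving a number 21.3 percentage points higher from compound 3 to compound 4 (beyond the scatter), so the direction of the change carries over to the core of compound 3, but its size does not: the same change on two cores in this assay, a number 38.8 percentage points higher (beyond the scatter) from compound 1 to compound 2 and a number 21.3 percentage points higher (beyond the scatter) from compound 3 to compound 4, 17.5 percentage points apart, beyond the scatter of two such steps

Read the other way round, the replacement of piperidin-1-yl by (4-chlorophenyl)amino gives a number 6 percentage points lower from compound 2 to compound 4 (within the scatter), so the rise it brought on the 4-chlorophenyl compounds is not seen on the 3,4-dichlorophenyl compounds: the same change on two cores in this assay, a number 11.5 percentage points higher (beyond the scatter) from compound 1 to compound 3 and a number 6 percentage points lower (within the scatter) from compound 2 to compound 4, 17.5 percentage points apart, beyond the scatter of two such steps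

This shows that in these four compounds the two changes do not simply add up and that the step from the added chloro depends on the core, but it rests on a single pair of cores and gives no rule for any other core, nor any reason for the difference.

The compounds shown leave open whether a fluoro or methoxy group in place of the added chloro would give a similar step on either core. They also leave open how morpholin-4-yl at the place of piperidin-1-yl, or a carboxylic acid in place of the ethyl ester, would fit in.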